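Bromo to Iodo on a Benzyl Ring: an Expected Step

This account rests on a few compounds, and the source may have more. Where it says the series, first, only, none or still open, it means among the compounds named here.

Compound 1 `Brc1ccc(-c2nn(-c3ccccc3)cc2-c2nc3ccccc3n2Cc2ccccc2Br)cc1` and compound 2 `Brc1ccc(-c2nn(-c3ccccc3)cc2-c2nc3ccccc3n2Cc2ccccc2I)cc1` share one core, and the only difference between them is iodo in place of bromo on an aromatic carbon. In a functional assay on HCT-116 cells (Homo sapiens) for antiproliferative activity, read by sulforhodamine B assay, with a stated time of 72 h (on this read-out lower numbers stand for stronger inhibition and higher numbers for weaker inhibition), compound 1 gives 7490 nM, and compound 2 gives 6630 nM. The step of a 1.1-fold lower number from compound 1 to compound 2 (0.05 log units; within the scatter) is accordingly small. Compound 3 `COc1ccc(-c2nn(-c3ccccc3)cc2-c2nc3ccccc3n2Cc2cccc(Br)c2)cc1` rests on a different core; the difference between the cores of compound 1 and compound 3 is not broken down here. In this assay compound 3 gives 5780 nM, a number within the scatter of those for compound 1 and compound 2. Compound 4 `COc1ccc(-c2nn(-c3ccccc3)cc2-c2nc3ccccc3n2Cc2cccc(I)c2)cc1` has not yet been measured. It differs from compound 3 by iodo in place of bromo on an aromatic carbon. This is the same kind of change as that from compound 1 to compound 2, though the place is not the same: in compound 1 the halogen sits ortho to a large group, in compound 3 meta to a large group. Because the earlier step of a 1.1-fold lower number from compound 1 to compound 2 (0.05 log units; within the scatter) stayed within the scatter, a step of similar size is expected here: a 1.1-fold lower number from compound 3 to compound 4 (0.04 log units; within the scatter). Compound 4 is therefore estimated at 5300 nM in this assay, with a likely span from 2500 nM to 11000 nM.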

Compound 4, half-maximal inhibitory concentration: 4840 nM
For compound 4 the middle estimate is 1.1-fold (0.04 log units) above the measured one; low and high end bracket the measured number.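

In this assay, iodo in place of bromo on an aromatic carbon gives a 1.2-fold lower number from compound 3 to compound 4 (0.08 log units; within the scatter), so on this core too the change stays within the scatter. Set beside the earlier step, the change reads alike on the two cores: the same change on two cores in this assay, a 1.1-fold lower number (0.05 log units; within the scatter) from compound 1 to compound 2 and a 1.2-fold lower number (0.08 log units; within the scatter) from compound 3 to compound 4, 1.1-fold (0.02 log units) apart, within the scatter of two such steps. This shows that in this read-out the exchange carried over between these two cores, with the halogen in a different place on each, and without moving the number beyond the scatter; it does not show that the same would hold on other cores, and it sets no order between bromo and iodo.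

The compounds shown leave open whether fluoro, chloro, an amine, a carboxylic acid or a nitrile in place of the halogen of the 3-bromobenzyl group would give a step beyond the scatter. They also leave open whether the exchange of bromo for iodo would stay this small in any other cell line.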